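A few compounds are considered here, and "the series" means these few. Any claim that something is new, unique, unknown or untested is made for them only; others in the source may bear on it.

The measured compounds in a physicochemical assay for lipophilicity; a higher number here means a more lipophilic compound, a lower number a more polar compound:

- compound 1, `N=C(N)Nc1cccc(C(=O)NNC(=O)CC(CC(=O)O)c2ccc(Br)cc2)c1`, gives 1.95
- compound 2, `COc1ccc(C(CC(=O)O)CC(=O)NNC(=O)c2cccc(NC(=N)N)c2)cc1`, gives 1
- compound 3, `N=C(N)Nc1cccc(C(=O)NNC(=O)NC(CC(=O)O)c2ccc(Br)cc2)c1`, gives 1.53

Compound 1 and compound 2 share one core and differ in a single place: methoxy in place of bromo on an aromatic carbon. In this assay that change gave a number 0.95 log units lower from compound 1 to compound 2 (beyond the scatter). Compound 3 is built on a different core; the difference between the core of compound 1 and the core of compound 3 is not broken down here. In this assay compound 3 stands second highest of the three, with compound 1 higher and compound 2 lower.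

Compound 4, `COc1ccc(C(CC(=O)O)NC(=O)NNC(=O)c2cccc(NC(=N)N)c2)cc1`, has not yet been measured. It relates to compound 3 exactly as compound 2 relates to compound 1: methoxy in place of bromo on an aromatic carbon. The place of the change reads the same word for word in both pairs, so this is the same change carried out on a different core. Among the compounds shown, it occurs twice in all, and only the first pair has numbers. The expectation for compound 4 therefore rests on that one earlier pair alone, because a number 0.95 log units lower from compound 1 to compound 2 (beyond the scatter). A step of similar size is expected here, so that a number 0.95 log units lower from compound 3 to compound 4 (beyond the scatter). For compound 4 in this assay the expected value is 0.58, with a likely range from 0.2 to 1.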

Compound 4, partition coefficient: 0.58
Compound 4: middle estimate and measured number agree at the digits printed; the measured number falls inside the stated range.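

Swapping bromo for methoxy on the core of compound 3 gave a number 0.95 log units lower from compound 3 to compound 4 (beyond the scatter) in this assay, and the same swap on the other core gave a number 0.95 log units lower from compound 1 to compound 2 (beyond the scatter). The two steps match at the digits printed, so in these two pairs the change carried from one core to the other with its size unchanged, but two pairs on two cores are a single agreement and not a rule that would hold on any further core. Nothing measured here bears on why the step has this size or why it repeats.

The compounds shown carry only bromo or methoxy at this place on the ring, so it remains open whether chloro, an amine or a longer chain such as ethoxy would also give matching steps on the two cores. As far as these compounds go, it also remains open whether the bromo to methoxy step would keep its size on a core that differs more widely, for example one with an ester in place of the carboxylic acid, or one without the guanidine group.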